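A few compounds are considered here, and "the series" means these few. Any claim that something is new, unique, unknown or untested is made for them only; others in the source may bear on it.

Of the compounds shown here, two have been measured in an assay on membranes from Cerebral cortex for displacement of a labelled ligand from Sigma non-opioid intracellular receptor 1 (Cavia porcellus), read by scintillation counting, with a stated time of 120 min (a lower number here means a stronger inhibitor, a higher number a weaker inhibitor), so far. Compound 1 `COc1ccc(C(C)CCN2CCCCC2)cc1` gives 20 nM in this assay. Compound 2 `CC(CCN(C)C)c1ccccc1` gives 427 nM in this assay, the higher of the two numbers, and its gap to compound 1 lies beyond the usual scatter. Compound 2 and compound 1 differ in two places at once, so their two values alone cannot tell which change carries that gap.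

Compound 3 `COc1ccc(C(C)CCN(C)C)cc1` has not yet been measured. It differs from compound 2 in one place: methoxy in place of hydrogen on an aromatic carbon. This is the same methoxy that compound 1 carries on its aromatic ring, while the amine end of compound 3 remains as in compound 2. Because compound 1 reaches 20 nM with that methoxy present, a downward step is expected here, but only part of the whole gap between compound 2 and compound 1 should be credited to it, as the second change is absent. The expected step is a 3.3-fold lower number from compound 2 to compound 3 (0.52 log units; beyond the scatter), beyond the scatter though modest. Compound 3 is therefore estimated at 130 nM, within a range from 45 nM to 380 nM.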

Compound 3, inhibition constant: 116 nM
For compound 3 the middle estimate is 1.1-fold (0.05 log units) above the measured one; the measured number falls inside the stated range.
By their numbers in this assay, from the lowest: compound 1; then compound 3; then compound 2.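

Compound 3 separates the two changes that were tangled together between compound 2 and compound 1, so each can now be read alone in this assay. Methoxy in place of hydrogen on an aromatic carbon, para to a group of 7 heavy atoms, gives a 3.7-fold lower number from compound 2 to compound 3 (0.57 log units; beyond the scatter), while the swap of dimethylamino for piperidin-1-yl on a saturated chain carbon, three bonds along the chain from an aromatic carbon, gives a 5.8-fold higher number from compound 1 to compound 3 (0.76 log units; beyond the scatter), and with both steps beyond the usual scatter, neither change alone carries the whole gap. Nothing measured here explains why either change moves the number.

A compound with piperidin-1-yl at the amine end and hydrogen on the aromatic carbon would show whether the two steps simply add up or whether each depends on the other. Going by these compounds, it also remains open how a hydroxy or ethoxy group would compare with methoxy on that aromatic carbon, and how a pyrrolidin-1-yl or morpholin-4-yl group would compare with the two amine ends seen so far.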